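The source may hold more compounds than are shown below. What is called first, only, known or untested is meant among the compounds shown, and "the series" means these compounds.

Compound 1 `COc1ccc(F)cc1N1C(=O)CSC1c1cccc(C(=O)NCCCCn2cccn2)c1`: 421 mL.min-1.g-1; compound 2 `O=C(NCCCCn1cccn1)c1cccc(C2SCC(=O)N2c2ccccn2)c1`: 82.1 mL.min-1.g-1; compound 3 `O=C(NCCCCc1ccccc1)c1cccc(C2SCC(=O)N2c2ccccn2)c1`: 412 mL.min-1.g-1.

In an ADME assay on microsomes from liver (Homo sapiens) for metabolic stability, read by LC-MS, using NADPH, with a stated time of 10 min, tested at 0.1 uM (on this read-out higher numbers stand for fast clearance and lower numbers for slow clearance), compound 3 stands second highest of the three, with compound 1 within the scatter of it, and compound 2 well beyond, being the lowest by a 5.0-fold higher number from compound 2 to compound 3 (0.70 log units; beyond the scatter).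

Compound 4 `C#Cc1cccc(N2C(=O)CSC2c2cccc(C(=O)NCCCCc3ccccc3)c2)c1` carries 3-ethynylphenyl in place of pyridin-2-yl on an amide-type nitrogen in a ring. Going by the values given here, the one measured step that changes the group on the amide-type nitrogen in a ring is a 5.1-fold lower number from compound 1 to compound 2 (0.71 log units; beyond the scatter), where the pyridin-2-yl entered; here it leaves, so a step of similar size in the opposite direction, towards higher numbers, is expected in this assay. Compound 4 is therefore estimated at 1000 mL.min-1.g-1, with a range of 450 mL.min-1.g-1 to 2200 mL.min-1.g-1, which corresponds to an expected 2.4-fold higher number from compound 3 to compound 4 (0.39 log units; beyond the scatter).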

Compound 4, intrinsic clearance in microsomes: 751 mL.min-1.g-1
Beside the measured number, compound 4's estimate is 1.3-fold (0.12 log units) above it; low and high end bracket the measured number.
By their numbers in this assay, from the lowest: compound 2; then compounds 3, 1 and 4 (each within the scatter of the next).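

Swapping pyridin-2-yl for 3-ethynylphenyl on the amide-type nitrogen, with the phenyl chain end kept, gives no clear change in this assay: the result is a 1.8-fold higher number from compound 3 to compound 4 (0.26 log units; within the scatter). Pyridin-2-yl therefore does not lower this number in every setting, although its earlier step with the 1H-pyrazol-1-yl chain end, a 5.1-fold lower number from compound 1 to compound 2 (0.71 log units; beyond the scatter), began from a different group. Nothing shown explains this difference between the two steps.

Open, going by these compounds, is how 3-ethynylphenyl reads with the 1H-pyrazol-1-yl chain end. Also open, on these data alone, is how a phenyl ring carrying an amine or a carboxylic acid would read on this nitrogen.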